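The source may hold more compounds than are shown below. What is called first, only, known or untested is meant among the compounds shown, and "the series" means these compounds.

Measured so far in an assay on membranes from HEK293 cells for displacement of a labelled ligand from adenosine receptor A2b (Homo sapiens), read by scintillation counting, with a stated time of 30 min, tested at 1 uM; on this read-out lower numbers stand for less inhibition and higher numbers for more inhibition at the one concentration tested (going by the name of the read-out): compound 1 `CCCC(=O)C1=C(C)NC(=O)NC1c1cccs1` gives 9%; compound 2 `CC1=C(C(=O)CC(C)C)C(c2cccs2)NC(=O)N1` gives 43%; compound 3 `CCN(CC)C(=O)C1=C(C)NC(=O)NC1c1cccs1` gives 22%.

Compound 3 stands second highest of the three numbers: a number 13 percentage points higher from compound 1 to compound 3 (beyond the scatter) and a number 21 percentage points lower from compound 2 to compound 3 (beyond the scatter). Compound 4 `CC1=C(C(=O)SC(C)C)C(c2cccs2)NC(=O)N1` differs from compound 3 by isopropylsulfanyl in place of diethylamino on a carbonyl carbon. The two steps that swap the group on the carbonyl carbon bear on this change, one modest upward, one modest downward, and the branched chain of compound 2 sits at the top of the set, with a number 34 percentage points higher from compound 1 to compound 2 (beyond the scatter) the largest step seen. The branched isopropylsulfanyl group is therefore expected to give a modest rise in this assay, though the direction is uncertain. Compound 4 is estimated at 30% with a range of 10% to 55%. The expected step is a number 8 percentage points higher from compound 3 to compound 4 (within the scatter).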

Compound 4, a percentage reported as inhibition, at one concentration (the size of the read-out at that concentration, not a potency): 1%
The estimate for compound 4 lay 29 percentage points above the measured number; the whole stated range lies above it.
By their numbers in this assay, from the lowest: compounds 4 and 1 (each within the scatter of the next); then compound 3; then compound 2.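

In this assay, isopropylsulfanyl in place of diethylamino on the carbonyl carbon gives a number 21 percentage points lower from compound 3 to compound 4 (beyond the scatter), and in place of isobutyl it gives a number 42 percentage points lower from compound 2 to compound 4 (beyond the scatter). A branched group at this place therefore does not by itself bring the higher number of compound 2. In place of propyl, the change gives a number 8 percentage points lower from compound 1 to compound 4 (within the scatter). No measurement available here explains the change.

Still open, from the compounds shown here alone, is whether the sulfur or the shape of the branch matters more. An isopropoxy group or a butyl chain on the carbonyl carbon would test this.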